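Cyano to hydroxy: notes toward compound 4

The compounds below may be only part of what the source reports. "The series", "measured", "known", "first", "only" and "open" are said of these compounds alone.

Values in a functional assay on MCF7 cells (Homo sapiens) for inhibition, read by sulforhodamine B assay, with a stated time of 48 h (a higher number here means a weaker inhibitor of growth, a lower number a stronger inhibitor of growth), for the three measured compounds:
compound 1 `O=C1CC(c2ccc(F)cc2)Nc2c(Br)cc(Br)cc21` gives < 100 nM, a limit of the assay.
compound 2 `O=C1CC(c2ccc(Cl)cc2)Nc2c(Br)cc(Br)cc21` gives 146 nM.
compound 3 `N#Cc1ccc(C2CC(=O)c3cc(Br)cc(Br)c3N2)cc1` gives < 100 nM, again a limit of the assay.

Compound 3 thus stands at the limit of < 100 nM in this assay, at which 2 of the 3 values shown sit, and no number is known for it. Compound 4 `O=C1CC(c2ccc(O)cc2)Nc2c(Br)cc(Br)cc21` differs by hydroxy in place of cyano on an aromatic carbon. Among the measured compounds shown here, no measured step involves hydroxy. The nearest steps are an at least 1.4-fold higher number from compound 1 to compound 2 (0.16 log units; that floor lies within the scatter) and an at least 1.4-fold lower number from compound 2 to compound 3 (0.16 log units; that floor lies within the scatter), both only floors that lie inside the scatter, while a step that the two limits leave unreadable from compound 1 to compound 3. These give no direction for the exchange, so in this assay a step no larger than the scatter is expected, an at least 1.2-fold higher number from compound 3 to compound 4 (0.07 log units; that floor lies within the scatter). For compound 4 the estimated value is 120 nM, with a range from 40 nM to 400 nM.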

Compound 4, concentration for 50% growth inhibition: < 100 nM
Compound 4 gave a limit, no number; the forecaster's own chance of this, stated with the estimate: 35%; at least 1.2-fold (0.07 log units) between middle value and limit.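

In this assay compound 4 gives < 100 nM, which is a limit of the assay. Hydroxy brings a hydrogen-bond donor that cyano lacks, yet at this place, para to a large group, it still leaves the compound at the same limit as the fluoro and cyano compounds: the limit of < 100 nM in this assay, at which 3 of the 4 values shown sit. The one readable step is an at least 1.4-fold lower number from compound 2 to compound 4 (0.16 log units; that floor lies within the scatter), and the steps that involve the other two limits cannot be read.

Going by these compounds, how the fluoro, cyano and hydroxy compounds rank stays open, as none has a number. On these data alone, an amine or a carboxylic acid at this place also remains open in this assay.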